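Swapping Propoxy for Butyl on the Shared Core

The source may report more compounds than this note shows. Statements on the series, on what has been measured and on what is new or still open speak of the compounds shown alone.

Measured in a functional assay on the whole organism with Rattus norvegicus as the target, at a dose of 3 mg/kg by the oral route; a lower number here means a weaker effect, a higher number a stronger effect of the compound at the dose given:
Compound 1, `CCCOc1cc(C(=O)Nc2nn[nH]n2)nc(-c2ccccc2)c1`, gives 100%.
Compound 2, `CCCOc1cc(C(=O)Nc2nn[nH]n2)nc(-c2ccc(N)cc2)c1`, gives 68%.
Compound 3, `COc1cccc(-c2cc(C)cc(C(=O)Nc3nn[nH]n3)n2)c1`, gives 65%.

Compound 1 stands highest of these three numbers. Among the compounds with values here, the only single-change step measured, a number 32 percentage points lower from compound 1 to compound 2 (beyond the scatter), shows that amino in place of hydrogen on an aromatic carbon lowers the read-out. Compound 3 also reads lower than compound 1, but it differs in more than one place. Compound 4, `CCCCc1cc(C(=O)Nc2nn[nH]n2)nc(-c2ccccc2)c1`, departs from compound 1 by a different change: butyl in place of propoxy on an aromatic carbon. Within the data shown here, no measured step concerns this place or this kind of exchange, so the expectation rests only on where compound 1 stands. Compound 4 is therefore expected to stay near it, an estimated step of a number 15 percentage points lower from compound 1 to compound 4 (beyond the scatter), giving an estimate of 85% with a range from 55% to 100%.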

Compound 4, a percentage reported as inhibition, in the whole organism at one dose (the size of the read-out at that dose, not a potency): 71%
Estimate against measurement, compound 4: 14 percentage points above, and the stated range covers the measured number.
By their numbers in this assay, from the lowest: compounds 3, 2 and 4 (each within the scatter of the next); then compound 1.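

In this assay butyl in place of propoxy gives a number 29 percentage points lower from compound 1 to compound 4 (beyond the scatter) and so this position, untouched by the earlier step on the phenyl group, also moves the read-out. The two chains have the same count of heavy atoms, and the difference is that an oxygen, counted as a hydrogen-bond acceptor, gives way to carbon. Matching that count therefore does not keep the read-out of compound 1.

The compounds shown leave open whether the oxygen itself counts, and how an ethoxy chain, a pentyloxy chain or an amine would read at this place. Nothing measured here gives a reason for the drop.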